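A few compounds are considered here, and "the series" means these few. Any claim that something is new, unique, unknown or untested is made for them only; others in the source may bear on it.

Of the compounds shown here, three have so far been tested in a functional assay on HepG2 cells (Homo sapiens) for cytotoxicity, read by MTT assay, with a stated time of 24 h; on this read-out lower numbers stand for stronger inhibition and higher numbers for weaker inhibition. Compound 1 `CN1C/C(=C\c2cccnc2)C(=O)/C(=C/c2cc([N+](=O)[O-])ccc2F)C1` gives 6630 nM, compound 2 `CN1C/C(=C\c2ccncc2)C(=O)/C(=C/c2ccc(C(F)(F)F)cc2)C1` gives 8200 nM, and compound 3 `Cc1ccc(S(=O)(=O)N2C/C(=C\c3cccnc3)C(=O)/C(=C/c3ccccc3F)C2)cc1` gives 4200 nM. These three numbers all lie within the usual scatter of one another, so compound 3 stands level with the other two. Compound 4 `O=C1/C(=C/c2cccnc2)CN(S(=O)(=O)c2ccc(Cl)cc2)C/C1=C\c1ccccc1F` differs from compound 3 in one place: chloro in place of methyl on an aromatic carbon. Here 4-methylphenyl becomes 4-chlorophenyl, with chloro in place of methyl on an aromatic carbon. For the measured compounds named here, no measured pair differs in only one place, so the data offer no direct guide, and no step beyond the scatter is expected in this assay. The expected step is a 1.1-fold lower number from compound 3 to compound 4 (0.02 log units; within the scatter). For compound 4 the estimated value is 4000 nM, with a range from 2000 nM to 8000 nM.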

Compound 4, half-maximal inhibitory concentration: 12400 nM
Estimate against measurement, compound 4: 3.1-fold (0.49 log units) below; the measured number lies above the stated range.
By their numbers in this assay, from the lowest: compounds 3, 1, 2 and 4 (each within the scatter of the next, the first and the last beyond it).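

Chloro in place of methyl on this aromatic carbon brings a 3.0-fold higher number from compound 3 to compound 4 (0.47 log units; beyond the scatter) in this assay and gives the first change in a single place that can be read here. The number at this position therefore responds to what sits on the ring, at least for this one swap. Nothing on hand gives a reason for the step. Going by these compounds, whether a methoxy group or an amine at the same place would give a higher or lower number stays open, as does whether this swap acts the same way on other compounds.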